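The compounds below may be only part of what the source reports. "The series", "measured", "known", "first", "only" and "open" are said of these compounds alone.

Working notes on the series. Compound 1 `N#C/C(=C\c1c(-c2ccccc2)[nH]c2ccccc12)C(=O)c1ccccc1` carries a benzoyl arm on the shared core. In a functional assay on RPMI-8226 cells (Homo sapiens) for inhibition, read by sulforhodamine B assay, with a stated time of 48 h (a higher number here means a weaker inhibitor of growth, a lower number a stronger inhibitor of growth), compound 1 gives 2400 nM. The two phenylsulfonyl analogues measured so far are compound 2 `COc1ccc(-c2[nH]c3ccc(OC)cc3c2/C=C(\C#N)S(=O)(=O)c2ccccc2)cc1`, which in this assay gives 1300 nM, and compound 3 `COc1ccc(-c2[nH]c3ccccc3c2/C=C(\C#N)S(=O)(=O)c2ccccc2)cc1`, which gives 2100 nM. Compound 1 stands among three numbers that all lie within the scatter of one another; its gap to compound 3 is the smaller, its gap to compound 2 the larger, and neither counts as a difference. Within the data shown here, the only single-point step measured, hydrogen in place of methoxy on an aromatic carbon, is a 1.6-fold higher number from compound 2 to compound 3 (0.21 log units; within the scatter).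

Compound 4 `N#C/C(=C\c1c(-c2ccccc2)[nH]c2ccccc12)S(=O)(=O)c1ccccc1` is not yet measured. It differs from compound 1 by phenylsulfonyl in place of benzoyl on a double-bonded chain carbon bound to a double-bonded chain carbon and a triple-bonded carbon. Among the measured compounds shown here, no measured pair bears directly on this exchange: compound 2 and compound 3 both already carry phenylsulfonyl, so they show only that a methoxy matters little, not what benzoyl against phenylsulfonyl does. Compound 3, the nearest sulfonyl comparator, gives 2100 nM. On this basis no step beyond the scatter is expected. Compound 4 is therefore estimated at 2000 nM, with a range of 900 nM to 4500 nM. The expected step amounts to a 1.2-fold lower number from compound 1 to compound 4 (0.08 log units; within the scatter).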

Compound 4, concentration for 50% growth inhibition: 714 nM
Compound 4: the middle estimate sits 2.8-fold (0.45 log units) above what was measured, outside the stated range (below it).
By their numbers in this assay, from the lowest: compounds 4, 2, 3 and 1 (each within the scatter of the next, the first and the last beyond it).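

In this assay, among these compounds, phenylsulfonyl in place of benzoyl at this position, on a double-bonded chain carbon bound to a double-bonded chain carbon and a triple-bonded carbon, gives the first step that lies beyond the scatter (a 3.4-fold lower number from compound 1 to compound 4 (0.53 log units; beyond the scatter)). This is a modest step, but it shows that the number responds to the group held at this carbon, which compounds 1, 2 and 3, all within the scatter of one another, could not show. Hydrogen in place of methoxy on an aromatic carbon also no longer reads as uniformly silent: the step stays within the scatter at one aromatic carbon (a 1.6-fold higher number from compound 2 to compound 3 (0.21 log units; within the scatter)) and goes beyond it at another (a 2.9-fold lower number from compound 3 to compound 4 (0.47 log units; beyond the scatter)), and no data on the compounds shown explain either result.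

Going by these compounds, the benzoyl to phenylsulfonyl exchange is seen on a single background, so whether it gives a step of similar size on the methoxy-bearing compounds remains open. Also open, on these data alone, is how this carbon responds to groups outside the aromatic pair, such as methylsulfonyl, a carboxylic acid or an amide.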